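The source may hold more compounds than are shown below. What is called first, only, known or untested is meant among the compounds shown, and "the series" means these compounds.

Three compounds share one core and differ only in the group carried on a phenyl ring attached to a triazole. Compound 1 `N#CC1=C(N)Oc2c(c3nc4ccccc4nc3c3ccccc23)C12C(=O)N(Cc1cnnn1-c1ccc(Br)cc1)c1ccccc12` carries a bromo group there; in a functional assay on A549 cells (Homo sapiens) for antiproliferative activity, read by MTT assay, with a stated time of 48 h (on this read-out higher numbers stand for weaker inhibition and lower numbers for stronger inhibition), compound 1 gives 44300 nM. Compound 2 `N#CC1=C(N)Oc2c(c3nc4ccccc4nc3c3ccccc23)C12C(=O)N(Cc1cnnn1-c1ccc([N+](=O)[O-])cc1)c1ccccc12` carries a nitro group in the same place. In this assay compound 2 reaches only a limit, reported as > 50000 nM, so no exact number is known for it. Within the data shown here, the one measured step, an at least 1.1-fold higher number from compound 1 to compound 2 (0.05 log units; that floor lies within the scatter), therefore cannot be sized beyond its floor, and one of the two values sits at the limit of > 50000 nM in this assay, at which 1 of the 2 values shown sits. Both compounds stand at the weak end of what this assay can report.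

Compound 3 `N#CC1=C(N)Oc2c(c3nc4ccccc4nc3c3ccccc23)C12C(=O)N(Cc1cnnn1-c1ccc(S(N)(=O)=O)cc1)c1ccccc12` is the next step: sulfamoyl in place of nitro on an aromatic carbon, on an aromatic carbon of a six-membered aromatic ring of carbon only, para to a large group. The nitro-for-bromo exchange gave no visible change in this assay, and nothing measured here separates the sulfamoyl group from either neighbour. Compound 3 is therefore expected to stay near the weak end, with a step of about a number no higher from compound 2 to compound 3 (the limit leaves the size open) from compound 2 to compound 3. The estimate for compound 3 in this assay is 50000 nM, with a range from 20000 nM to 150000 nM.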

Compound 3, half-maximal inhibitory concentration: > 50000 nM
Compound 3 ended at the assay's limit; the forecaster's own chance of this, stated with the estimate: 55%; the middle value lies on the limit itself.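

Compound 3 puts a third group on the phenyl ring, para to a large group, and in this assay it too yields only a limit and not a number: the limit of > 50000 nM in this assay, at which 2 of the 3 values shown sit. The sulfamoyl group brings a sulfur and a hydrogen-bond donor that the nitro group lacks, yet this exchange still gives no exact value, so the steps between the two limit compounds cannot be read. Among these compounds, the one readable comparison is an at least 1.1-fold higher number from compound 1 to compound 3 (0.05 log units; that floor lies within the scatter), so the three groups tried at this place, bromo, nitro and sulfamoyl, are not told apart by anything measured here.

As far as these compounds go, how far compound 2 and compound 3 lie beyond their limits stays unknown, and so does the true size of any gap between them and compound 1. Also open, from the compounds shown here alone, is whether a different group on this phenyl ring, such as an amine or a carboxylic acid, would bring the number clearly down from the weak end of this assay.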